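Purine chloromethylbenzyl series: removing the second ring chlorine

A few compounds are considered here, and "the series" means these few. Any claim that something is new, unique, unknown or untested is made for them only; others in the source may bear on it.

Three compounds carry a chloromethylbenzyl group on the shared core. Compound 1 `ClCc1ccc(Cn2cnc3nc(Cl)nc(Cl)c32)cc1` gives 4460 nM in a functional assay on NCI/ADR-RES cells (Homo sapiens) for cytotoxicity, read by sulforhodamine B assay, with a stated time of 48 h; a higher number here means a weaker inhibitor of growth, a lower number a stronger inhibitor of growth. Compound 2 `ClCc1ccccc1Cn1cnc2ncnc(Cl)c21` gives 4460 nM in this assay, and compound 3 `Nc1nc(Cl)c2ncn(Cc3cccc(CCl)c3)c2n1` gives 20000 nM. Compound 1 therefore stands level with compound 2 at the digits shown, the two together being the lowest numbers of the three, while compound 3 sits at a higher number beyond the scatter; no single-point step links any of these pairs, so only the values themselves can be compared.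

Compound 4 `ClCc1ccc(Cn2cnc3ncnc(Cl)c32)cc1` is not yet measured. It differs from compound 1 by hydrogen in place of chloro on an aromatic carbon of a six-membered aromatic ring with 2 nitrogen, part of a fused or bridged system of two rings, between two ring nitrogen atoms. Compound 2, which likewise has hydrogen at that position on the core, gives 4460 nM, so no step beyond the scatter is expected from compound 1 to compound 4. Compound 4 is thus estimated at 5000 nM in this assay, within 2000 nM to 12000 nM, which means an expected step of a 1.1-fold higher number from compound 1 to compound 4 (0.05 log units; within the scatter).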

Compound 4, concentration for total growth inhibition: 4670 nM
Compound 4: middle estimate off by 1.1-fold (0.03 log units), on the high side; the range from low to high includes it.
By their numbers in this assay, from the lowest: compounds 1, 2 and 4 (each within the scatter of the next); then compound 3.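

Hydrogen in place of chloro on an aromatic carbon between two ring nitrogen atoms gives a 1.0-fold higher number from compound 1 to compound 4 (0.02 log units; within the scatter) in this assay and stays within the scatter. Within the data shown here, this is the only direct reading of this change, as the earlier compounds could be compared only by their separate values. With the chloromethylbenzyl group held fixed, the chloro group at this position can therefore be lost without a step beyond the scatter, and no measured data bear on the reason for this result.

On these data alone, only chloro and hydrogen are compared directly here, so the effect of a methyl, methoxy or nitrile group at this position remains open. The contribution of the remaining chloro group on the core also remains open, as does that of the chloromethyl group, since no step shown changes either one.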